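Swapping the Pendant Aryl Group on a Shared Kinase Scaffold

A few compounds are considered here, and "the series" means these few. Any claim that something is new, unique, unknown or untested is made for them only; others in the source may bear on it.

Of the compounds shown here, two sharing one core have been measured in an assay for binding affinity to dual specificity mitogen-activated protein kinase kinase 4 (Homo sapiens), read by KINOMEscan, tested at 100 nM; on this read-out higher numbers stand for a weaker effect at the one concentration tested and lower numbers for a stronger effect. Compound 1 `CCCS(=O)(=O)Nc1ccc(F)c(C(=O)c2n[nH]c3ncc(-c4ccccc4Cl)cc23)c1F` gives 9.3%. Compound 2 `CCCS(=O)(=O)Nc1ccc(F)c(C(=O)c2n[nH]c3ncc(-c4cccc(O)c4)cc23)c1F` gives 2.2%. Among the compounds with values here, the only measured step, a number 7.1 percentage points lower from compound 1 to compound 2 (within the scatter), lies within the scatter, so the two numbers cannot be told apart, and compound 2 simply stands alongside compound 1 at a strong level of binding.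

Compound 3 `CCCS(=O)(=O)Nc1ccc(F)c(C(=O)c2n[nH]c3ncc(-c4ccc(F)cc4C)cc23)c1F` is not yet measured. It differs from compound 2 as follows: 4-fluoro-2-methylphenyl in place of 3-hydroxyphenyl on an aromatic carbon

The step from compound 1 to compound 2 bears directly on this change, since it too swapped the group at this same aromatic carbon, and it produced no step beyond the scatter. The expectation is therefore that the change to compound 3 yields no step beyond the scatter either, with a number 5.8 percentage points higher from compound 2 to compound 3 (within the scatter) as the estimated shift. Compound 3 is expected to give about 8%, between 1% and 25%.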

Compound 3, a percentage reported as activity, at one concentration (the size of the read-out at that concentration, not a potency): 14%
For compound 3 the middle estimate is 6 percentage points below the measured one, within the range that was stated.
By their numbers in this assay, from the lowest: compounds 2, 1 and 3 (each within the scatter of the next, the first and the last beyond it).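

Within the data shown here, this change gives the first step at this aromatic carbon that lies beyond the scatter in this assay: a number 11.8 percentage points higher from compound 2 to compound 3 (beyond the scatter). The position therefore does respond to the choice of aryl group, though only modestly, and the comparison with the other ortho-free... 

Correction, final text:

Among these compounds, this change gives the first step at this aromatic carbon that lies beyond the scatter in this assay: a number 11.8 percentage points higher from compound 2 to compound 3 (beyond the scatter), so the choice of aryl group here can shift the read-out, if only modestly. The picture is not a clean split, since 4-fluoro-2-methylphenyl and 2-chlorophenyl cannot be told apart, with a number 4.7 percentage points higher from compound 1 to compound 3 (within the scatter), and compound 1 also lies within the scatter of compound 2. Nothing available explains why the number moved.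

The swap removes the hydroxyl while adding a methyl and a fluorine, so the compounds shown leave open which of these differences matters. Also open, on these data alone, is how an amine or a carboxylic acid on this aryl ring would read out.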